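Amine side chain shortened: from compound 2 to compound 3

The source may hold more compounds than are shown below. What is called first, only, known or untested is meant among the compounds shown, and "the series" means these compounds.

Measured in a functional assay on HepG2 cells (Homo sapiens), read by MTT assay, with a stated time of 48 h (on this read-out lower numbers stand for stronger inhibition and higher numbers for weaker inhibition), so far:
compound 1 `CCN(CC)CCNC(=O)c1ccc(C(CC)(CC)c2ccc(OCC(=O)C(C)(C)C)c(C)c2)n1CC` gives 620 nM
compound 2 `CCn1c(C(=O)NCCCN(C)C)ccc1C(CC)(CC)c1ccc(OCC(=O)C(C)(C)C)c(C)c1` gives 960 nM

Compound 2 lies within the scatter of compound 1, so the two cannot be ordered. Within the data shown here, compound 3 `CCn1c(C(=O)NCCN)ccc1C(CC)(CC)c1ccc(OCC(=O)C(C)(C)C)c(C)c1` is still unmeasured and differs from compound 2 as follows: amino in place of (dimethylamino)methyl on a saturated chain carbon, two bonds along the chain from an amide-type nitrogen, at the same chain position as the one measured change. Among the measured compounds shown here, that change, a 1.5-fold higher number from compound 1 to compound 2 (0.19 log units; within the scatter), is the only step bearing on this one. No shift beyond the scatter is therefore expected in this assay, and no direction is favoured. The expected step is a 1.0-fold higher number from compound 2 to compound 3 (0.02 log units; within the scatter) on this basis. The estimate for compound 3 is 1000 nM (350 nM to 2800 nM) as an expected value.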

Compound 3, half-maximal inhibitory concentration: 180 nM
The estimate for compound 3 lay 5.6-fold (0.74 log units) above the measured number; measured number outside the range, below it.
By their numbers in this assay, from the lowest: compound 3; then compounds 1 and 2 (each within the scatter of the next).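

In this assay, the end of this side chain does respond to change: amino in place of (dimethylamino)methyl gives a 5.3-fold lower number from compound 2 to compound 3 (0.73 log units; beyond the scatter), although the earlier step between compound 1 and compound 2 stayed within the scatter. Amino in place of diethylamino, on the same chain, gives a 3.4-fold lower number from compound 1 to compound 3 (0.54 log units; beyond the scatter), so the lower number appears without any change in chain length. Still open, from the compounds shown here alone, is how a single ethylamino end would read, and whether an unsubstituted amino end on the longer 3-aminopropyl chain would keep the lower number. No measurement available here accounts for the shift.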